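From 2-fluorobenzyl to 3-chlorobenzyl: working notes on the series

A few compounds are considered here, and "the series" means these few. Any claim that something is new, unique, unknown or untested is made for them only; others in the source may bear on it.

Within the data shown here, in an ADME assay on HEK293 cells (Homo sapiens) for cytotoxicity, read by MTT assay, with a stated time of 24 h (a lower number here means a stronger inhibitor, a higher number a weaker inhibitor), compound 1 (`O=C1/C(=C/c2ccccc2F)CN(Cc2cn(Cc3ccccc3F)nn2)C/C1=C\c1ccccc1F`) gives 41200 nM, the only numeric value so far. Compound 2 (`COc1ccc(/C=C2\CN(Cc3cn(Cc4cccc(Cl)c4)nn3)C/C(=C\c3ccc(OC)cc3)C2=O)cc1`) reads > 100000 nM, which is a limit of the assay and not a number. Compound 3 (`O=C1/C(=C/c2ccccc2F)CN(Cc2cn(Cc3cccc(Cl)c3)nn2)C/C1=C\c1ccccc1F`) remains unmeasured. It carries 3-chlorophenyl in place of 2-fluorophenyl on a saturated chain carbon bound to an aromatic nitrogen. Among the measured compounds shown here, no measured step covers this change, so the expectation in this assay starts from compound 1 at 41200 nM, with no shift beyond the usual scatter. The expected change is a 1.2-fold higher number from compound 1 to compound 3 (0.08 log units; within the scatter). For compound 3 the estimate is 50000 nM, with an expected range of 20000 nM to 100000 nM.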

Compound 3, half-maximal inhibitory concentration: 33100 nM
Estimate against measurement, compound 3: 1.5-fold (0.18 log units) above; measured number inside the range.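

On a saturated chain carbon bound to an aromatic nitrogen, 3-chlorophenyl in place of 2-fluorophenyl gives, in this assay, a 1.2-fold lower number from compound 1 to compound 3 (0.10 log units; within the scatter). Among these compounds, this is the first readable step at this position, and in this assay the 2-fluorobenzyl and 3-chlorobenzyl groups cannot be told apart on this core. Nothing shown gives a cause for this step.

On these data alone, whether a benzyl group carrying an amine or a carboxylic acid would shift the number stays open. Compound 2 reads > 100000 nM, which is a limit and not a number.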